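This account rests on a few compounds, and the source may have more. Where it says the series, first, only, none or still open, it means among the compounds named here.

Measured so far:
compound 1 `CN(C)C(=O)c1sc(-c2ccc(Cl)cc2)nc1C(Br)Br` — 163000 nM
compound 2 `C=CCNC(=O)c1sc(-c2ccc(Cl)cc2)nc1C(Br)Br` — 40800 nM

In an ADME assay on BHK15 cells (Mesocricetus auratus) for inhibition, read by XTT assay, with a stated time of 36 h (on this read-out lower numbers stand for stronger inhibition of growth and higher numbers for weaker inhibition of growth), compound 2 holds the lowest of the two numbers; compound 1 sits a 4.0-fold lower number from compound 1 to compound 2 (0.60 log units; beyond the scatter) away from it. Compound 3 `CN(C)/C=C/C(=O)c1sc(-c2ccc(Cl)cc2)nc1C(Br)Br` is the one not yet measured. It differs from compound 2 by 2-(dimethylamino)ethenyl in place of allylamino on a carbonyl carbon. The only measured step, a 4.0-fold lower number from compound 1 to compound 2 (0.60 log units; beyond the scatter), also changes the group on the carbonyl carbon and shows a modest shift, so a change at this position can move the number beyond the scatter; which way the present change moves it is not shown by any pair. Compound 3 is expected to land near compound 2, with a step of a 1.5-fold higher number from compound 2 to compound 3 (0.17 log units; within the scatter), giving an estimate of 60000 nM within 15000 nM to 250000 nM.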

Compound 3, concentration for 50% growth inhibition: 38200 nM
Compound 3: the middle estimate sits 1.6-fold (0.20 log units) above what was measured; the measured number falls inside the stated range.
By their numbers in this assay, from the lowest: compounds 3 and 2 (each within the scatter of the next); then compound 1.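

In this assay, 2-(dimethylamino)ethenyl in place of allylamino on a carbonyl carbon gives a 1.1-fold lower number from compound 2 to compound 3 (0.03 log units; within the scatter), so this place tolerates the exchange of these two groups without a shift beyond the scatter. Set against dimethylamino, the same group gives a 4.3-fold lower number from compound 1 to compound 3 (0.63 log units; beyond the scatter), so two different replacements of dimethylamino now lower the number by a modest step. No measured evidence accounts for these results.

Going by these compounds, whether a carboxylic acid or a longer chain on this carbonyl carbon would lower the number further remains open.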